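Two Sulfonamides Below Detection and a Methyl Analogue Ahead

The source may hold more compounds than are shown below. What is called first, only, known or untested is meant among the compounds shown, and "the series" means these compounds.

The study concerns inhibitors of the enzyme examined in an assay on isolated protein for inhibition of malate dehydrogenase, mitochondrial (Sus scrofa), with stated times of 45 min and 30 min; on this read-out higher numbers stand for weaker inhibition and lower numbers for stronger inhibition. Compound 1 has the structure `C=Cc1ccc(S(=O)(=O)Nc2ccc(-c3nc4ccccc4o3)cc2)cc1`. In this assay compound 1 reaches only the limit of the assay, reported as > 63000 nM. Compound 2, `O=S(=O)(Nc1ccc(-c2nc3ccccc3o2)cc1)c1ccc(F)cc1`, differs from compound 1 by a fluoro in place of a vinyl on an aromatic carbon. In this assay compound 2 likewise gives only the limit of the assay, > 63000 nM. Among the measured compounds shown here, the single measured step, a step that the two limits leave unreadable from compound 1 to compound 2, thus cannot be read for size because of the limit of > 63000 nM in this assay, at which 2 of the 2 values shown sit. Compound 3, `Cc1cccc(S(=O)(=O)Nc2ccc(-c3nc4ccccc4o3)cc2)c1`, carries 3-methylphenyl in place of 4-fluorophenyl on a sulfonyl sulfur. For the measured compounds named here, no measured step resembles this change, and both values shown sit where (the limit of > 63000 nM in this assay, at which 2 of the 2 values shown sit). Compound 3 is therefore expected to remain at or near that limit, with an expected step that the limit leaves unreadable from compound 2 to compound 3. The estimate for compound 3 in this assay is 80000 nM, within an expected range from 25000 nM to 300000 nM.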

Compound 3, half-maximal inhibitory concentration: > 63000 nM
Compound 3: only a limit was reported (the forecaster's own chance of this, stated with the estimate: 80%); the middle value is on the limit's open side.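

Compound 3 gives > 63000 nM as a limit of the assay and not a number. Among the compounds shown here, no step among compound 1, compound 2 and compound 3 can be read: (the limit of > 63000 nM in this assay, at which 3 of the 3 values shown sit). The compounds shown leave open whether any group on the sulfonyl sulfur gives measurable inhibition.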